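The compounds below may be only part of what the source reports. "The series", "measured", "known", "first", "only" and "open" are said of these compounds alone.

Measured compounds:
- compound 1 `CCOc1ccc(-c2cc(=O)c3c(o2)C(CC)(CC)C(=O)C(CC)=C3O)cc1`: in a functional assay on KBVIN cells (Homo sapiens) for antiproliferative activity, read by sulforhodamine B assay, with a stated time of 3 days (on this read-out higher numbers stand for an effect only at larger amounts of compound and lower numbers for an effect already at smaller amounts), compound 1 gives 7.54 uM
- compound 2 `CCC1=C(O)c2c(oc(-c3ccc(Br)cc3)cc2=O)C(CC)(CC)C1=O`: compound 2 gives 15.7 uM
- compound 3 `CCC1=C(O)c2c(oc(-c3cc(C)c(C)cc3C)cc2=O)C(CC)(CC)C1=O`: compound 3 gives 4.37 uM

Compound 3 has the smallest number of the three. Against compound 2 the separation is clear, a 3.6-fold lower number from compound 2 to compound 3 (0.56 log units; beyond the scatter). Against compound 1 it is not: a 1.7-fold lower number from compound 1 to compound 3 (0.24 log units; within the scatter), so compounds 1 and 3 cannot be told apart on these data. Among the measured compounds shown here, the one step that stands beyond the scatter without touching compound 3, a 2.1-fold higher number from compound 1 to compound 2 (0.32 log units; beyond the scatter), swaps the group on the aromatic carbon of the shared core.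

Compound 4 `CCC1=C(O)c2c(oc(-c3cc(C)ccc3C)cc2=O)C(CC)(CC)C1=O` differs from compound 3 only at the aromatic ring: hydrogen in place of methyl on an aromatic carbon. None of the three measured steps removes a single methyl from that ring; each replaces the whole 4-ethoxyphenyl, 4-bromophenyl or 2,4,5-trimethylphenyl group, and the largest of them stays modest. For the measured compounds named here, no direct precedent for this change exists here, so no step beyond the scatter is expected in this assay. The expected step is a 1.3-fold higher number from compound 3 to compound 4 (0.10 log units; within the scatter). Compound 4 is estimated at 5.5 uM, with a range of 2.5 uM to 12 uM.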

Compound 4, concentration for half-maximal effect: 3.41 uM
The estimate for compound 4 lay 1.6-fold (0.21 log units) above the measured number, and the stated range covers the measured number.
By their numbers in this assay, from the lowest: compounds 4, 3 and 1 (each within the scatter of the next, the first and the last beyond it); then compound 2.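

In this assay, the methyl para to a large group can give way to hydrogen with a 1.3-fold lower number from compound 3 to compound 4 (0.11 log units; within the scatter) as the step, so methyl and hydrogen at this carbon cannot be told apart here. The 2,5-dimethylphenyl group also separates from both single-substituted rings, as a 2.2-fold lower number from compound 1 to compound 4 (0.34 log units; beyond the scatter) and a 4.6-fold lower number from compound 2 to compound 4 (0.66 log units; beyond the scatter) are each beyond the scatter and modest, whereas compound 3 could not be told apart from compound 1. Nothing available explains these steps.

Only hydrogen and methyl are seen at this ring carbon, so a methoxy group, a hydroxyl group or an amine there remains an open case. As far as these compounds go, whether each of the two remaining methyl groups matters on its own also stays open, as would a single 2-methylphenyl or 3-methylphenyl ring.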